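This account rests on a few compounds, and the source may have more. Where it says the series, first, only, none or still open, it means among the compounds named here.

Measured compounds:
- compound 1, `CCCCCCCCCCCCCCc1nc(OC2CCC2)nc(OC2CCC2)c1O`, in a functional assay on cells (Lymphocyte, Homo sapiens), read by a luciferase reporter and ATP content, with a stated time of 48 h, tested at 5 uM (on this read-out higher numbers stand for a weaker effect at the one concentration tested and lower numbers for a stronger effect), compound 1 gives 98%
- compound 2, `CCCCCCCCCCCCCCCCc1nc(OC2CCC2)nc(OC2CCC2)c1O`, compound 2 gives 102%
- compound 3, `CCCCCCCCCCCCCCc1nc(N2CCC2)nc(N2CCC2)c1O`, compound 3 gives 46%

Compound 2 is made from compound 1 by one change, (ethyl in place of hydrogen on a saturated chain carbon, ten or more bonds along the chain from an aromatic carbon), and the step it made is a number 4 percentage points higher from compound 1 to compound 2 (within the scatter). Compound 3 has a different core; the difference between the two cores is not broken down here. Compound 4, `CCCCCCCCCCCCCCCCc1nc(N2CCC2)nc(N2CCC2)c1O`, is not yet measured. It stands to compound 3 exactly as compound 2 stands to compound 1, by the same change, (ethyl in place of hydrogen on a saturated chain carbon, ten or more bonds along the chain from an aromatic carbon). Within the data shown here, since compound 1 and compound 2 show only the step of a number 4 percentage points higher from compound 1 to compound 2 (within the scatter), the same change on compound 3 is expected to make a step of about a number 3 percentage points higher from compound 3 to compound 4 (within the scatter). On that basis compound 4 is estimated to give 49%, in the range from 30% to 70%.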

Compound 4, a percentage reported as activity, at one concentration (the size of the read-out at that concentration, not a potency): 61%
Compound 4: the middle estimate sits 12 percentage points below what was measured; measured number inside the range.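

On the core of compound 3, ethyl in place of hydrogen on a saturated chain carbon, ten or more bonds along the chain from an aromatic carbon, gives a number 15 percentage points higher from compound 3 to compound 4 (beyond the scatter) in this assay. Set beside the same change on the core of compound 1, this step does not differ from the earlier one by more than the scatter of two such steps: the same change on two cores in this assay, a number 4 percentage points higher (within the scatter) from compound 1 to compound 2 and a number 15 percentage points higher (beyond the scatter) from compound 3 to compound 4, 11 percentage points apart, within the scatter of two such steps This shows that the change can be carried between these two cores as far as this read-out can tell, but with a single pair on each core it does not show that the two steps are truly equal or that the same would hold on any other core.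

The compounds shown leave open how a shorter chain would read on either core. They also leave open what an amine or a carboxylic acid in place of the chain would give.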